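This account rests on a few compounds, and the source may have more. Where it says the series, first, only, none or still open, it means among the compounds named here.

Measured so far in an ADME assay on HeLa cells (Homo sapiens) for cytotoxicity, read by microscopy; on this read-out lower numbers stand for higher toxicity in this test and higher numbers for lower toxicity in this test:
compound 1 `O=c1[nH]c(=O)n(C2C=CC(O)C2)cc1-c1cccs1`: 20000 nM
compound 2 `O=c1[nH]c(=O)n(C2C=CC(O)C2)cc1-c1ccco1`: > 100000 nM, a limit of the test rather than a measured number.

Within this pair, compound 2 stands at the upper edge of what the test reports: the limit of > 100000 nM in this assay, at which 1 of the 2 values shown sits. Among the measured compounds shown here, the only measured step, an at least 5.0-fold higher number from compound 1 to compound 2 (0.69 log units; beyond the scatter), is the sole guide to how exchanging the five-membered ring on the shared core moves the read-out, and it moved the number up beyond the scatter.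

Compound 3 `O=c1[nH]c(=O)n(C2C=CC(O)C2)cc1-c1cncs1` carries the change (1,3-thiazol-5-yl in place of furan-2-yl on an aromatic carbon). For the measured compounds named here, no measured step covers this exact exchange. The one step in this assay shows that swapping one five-membered aromatic ring for another at this position can shift the number beyond the scatter, but with compound 2 already sitting at the limit, a further rise cannot be resolved, and a fall back toward the value of compound 1 is possible but not indicated by any shown step. The expected step of a number no higher from compound 2 to compound 3 (the limit leaves the size open) is therefore taken as none beyond the scatter. Compound 3 is estimated at 100000 nM, with a range from 30000 nM to 300000 nM.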

Compound 3, minimum cytotoxic concentration: > 100000 nM
Compound 3 gave a limit, no number (the forecaster's own chance of this, stated with the estimate: 60%); the middle value sits exactly at the limit.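

In this assay compound 3 gives > 100000 nM, a limit of the test and not a number. The change from thiophen-2-yl to 1,3-thiazol-5-yl gives an at least 5.0-fold higher number from compound 1 to compound 3 (0.69 log units; beyond the scatter), so a second five-membered aromatic ring at this position, and one that contains sulfur, also leaves the level of compound 1; sulfur in this ring therefore does not by itself hold the number at that level. The step between furan-2-yl and 1,3-thiazol-5-yl cannot be read, since compound 2 and compound 3 both end at the same edge of the test: the limit of > 100000 nM in this assay, at which 2 of the 3 values shown sit.

Any order between compound 2 and compound 3 stays unknown, as neither has a number in this assay. On these data alone, only five-membered aromatic rings appear at this position, so it remains open whether a phenyl ring, an amine, a carboxylic acid or a longer chain there would bring the number down toward that of compound 1, and whether a change to the 4-hydroxycyclopent-2-en-1-yl group would move it.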